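The source may hold more compounds than are shown below. What is called first, only, known or untested is meant among the compounds shown, and "the series" means these compounds.

Of the compounds shown here, three carry a number so far. Compound 1 `N#C/C(=C\c1ccc[nH]1)C(=O)NCc1ccc(Cl)c(Cl)c1` gives 85000 nM in a functional assay on HT-29 cells (Homo sapiens) for inhibition, read by MTT assay, with a stated time of 72 h; a higher number here means a weaker inhibitor of growth, a lower number a stronger inhibitor of growth. Compound 2 `COc1ccc(CNC(=O)/C(C#N)=C/c2ccc(Cl)o2)cc1` gives 9000 nM in this assay, the lowest number of the three. Compound 3 `COc1ccc(CNC(=O)/C(C#N)=C/c2ccc(-c3ccccc3)o2)cc1` gives 56000 nM in this assay. Compound 1 and compound 2 differ in more than one place, so their two values are noted side by side without a step. Between compound 2 and compound 3 one step is known: a 6.2-fold higher number from compound 2 to compound 3 (0.79 log units; beyond the scatter).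

Compound 4 `COc1ccc(CNC(=O)/C(C#N)=C/c2ccc(C)cc2)cc1` is not yet measured. Relative to compound 2 the change is 4-methylphenyl in place of 5-chlorofuran-2-yl on a double-bonded chain carbon bound to a double-bonded chain carbon. For the measured compounds named here, the only measured step on this part of the structure is the one from compound 2 to compound 3, where a change on the aromatic ring attached to the double-bonded chain carbon raised the number modestly. The present change is larger, since the whole ring is exchanged, and the expectation is a step upward of similar or somewhat larger size, so that compound 4 is estimated at 35000 nM in this assay, within 9000 nM to 120000 nM, an expected step of a 3.9-fold higher number from compound 2 to compound 4 (0.59 log units; beyond the scatter).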

Compound 4, concentration for 50% growth inhibition: 36000 nM
Compound 4: middle estimate off by 1.0-fold (0.01 log units), on the low side, and the stated range covers the measured number.
By their numbers in this assay, from the lowest: compound 2; then compounds 4, 3 and 1 (each within the scatter of the next, the first and the last beyond it).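

In this assay, the whole ring can be exchanged at this place, and the result is a 4.0-fold higher number from compound 2 to compound 4 (0.60 log units; beyond the scatter). This is a second change away from 5-chlorofuran-2-yl that raises the number, alongside a 6.2-fold higher number from compound 2 to compound 3 (0.79 log units; beyond the scatter), so compound 2 remains lower than both compounds with a different group on the double-bonded chain carbon. No available evidence explains the rise at this place.

Compound 4 loses the chlorine and the furan ring together, so the compounds shown do not separate the part played by either one. A 4-chlorophenyl or a 5-methylfuran-2-yl group would separate them, while an amine or a carboxylic acid on the ring remains an open question at this place.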